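This account rests on a few compounds, and the source may have more. Where it says the series, first, only, none or still open, it means among the compounds named here.

Values in a functional assay on T98G cells (Homo sapiens) for inhibition, read by MTT assay, with a stated time of 72 h; on this read-out lower numbers stand for stronger inhibition and higher numbers for weaker inhibition:
- compound 1 `CC1(C)CC(NC(=S)Nc2cccc(C#N)c2)c2cc(Br)ccc2O1`: 9000 nM
- compound 2 `CC1(C)CC(NC(=S)Nc2ccc([N+](=O)[O-])cc2)c2cc(Br)ccc2O1`: 5000 nM
- compound 3 `COc1ccccc1NC(=S)NC1CC(C)(C)Oc2ccc(Br)cc21`: 42000 nM

Compound 3 carries the highest number of the three, beyond the scatter from both others. Compound 4 `CC1(C)CC(NC(=S)Nc2ccc(Cl)cc2)c2cc(Br)ccc2O1` differs from it as follows: 4-chlorophenyl in place of 2-methoxyphenyl on an amide-type nitrogen. In short, 4-chlorophenyl stands in place of 2-methoxyphenyl on an amide-type nitrogen. Among the measured compounds shown here, the one measured step bearing on this is a 4.7-fold higher number from compound 1 to compound 3 (0.67 log units; beyond the scatter), where the 2-methoxyphenyl group enters; here it leaves. Compound 2, also without that group, gives 5000 nM. For the measured compounds named here, no measured compound carries 4-chlorophenyl, so the read-across is loose. Expected in this assay is a 5.3-fold lower number from compound 3 to compound 4 (0.72 log units; beyond the scatter), a drop beyond the scatter. For compound 4 the estimate is 8000 nM, with an expected range of 3000 nM to 22000 nM.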

Compound 4, half-maximal inhibitory concentration: 22000 nM
Compound 4: the middle estimate sits 2.8-fold (0.44 log units) below what was measured, within the range that was stated.
By their numbers in this assay, from the lowest: compounds 2 and 1 (each within the scatter of the next); then compounds 4 and 3 (each within the scatter of the next).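

In this assay, 4-chlorophenyl in place of 2-methoxyphenyl gives a 1.9-fold lower number from compound 3 to compound 4 (0.28 log units; within the scatter), so losing the 2-methoxyphenyl group does not by itself bring the number to the level of the 3-cyanophenyl or 4-nitrophenyl compounds. The group on this amide-type nitrogen still separates these compounds, with a 4.4-fold higher number from compound 2 to compound 4 (0.64 log units; beyond the scatter) and a 2.4-fold higher number from compound 1 to compound 4 (0.39 log units; beyond the scatter). No evidence at hand accounts for these steps.

Open, from the compounds shown here alone, is how an amine or a carboxylic acid in place of chloro on the aromatic carbon would read in this assay.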